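From Methyl to Methoxy on the Phenyl Ring

The compounds below may be only part of what the source reports. "The series", "measured", "known", "first", "only" and "open" are said of these compounds alone.

Compound 1, `CCc1nn(C)c(CO/N=C/c2c(C)nn(C)c2Oc2ccc(F)cc2)c1Cl`, gives < 80% in a functional assay on SMMC-7721 cells (Homo sapiens) for inhibition, read by MTT assay, with a stated time of 72 h, tested at 25 uM (a lower number here means less inhibition, a higher number more inhibition at the concentration tested (going by the name of the read-out)), which is a limit of the assay and not a number.
Compound 2, `CCc1nn(C)c(CO/N=C/c2c(C)nn(C)c2Oc2ccc(I)cc2)c1Cl`, gives < 80% in this assay, again a limit.
Compound 3, `CCc1nn(C)c(CO/N=C/c2c(C)nn(C)c2Oc2ccccc2C)c1Cl`, gives < 80% in this assay, also a limit.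

Compound 3 therefore stands nowhere in particular on a scale: its value is a limit, and the two other values shown share it, as the limit of < 80% in this assay, at which 3 of the 3 values shown sit, records. The steps a step that the two limits leave unreadable from compound 1 to compound 2, a step that the two limits leave unreadable from compound 1 to compound 3 and a step that the two limits leave unreadable from compound 2 to compound 3 are all unreadable for this reason, so none of them gives a size that could be carried forward.

Compound 4, `CCc1nn(C)c(CO/N=C/c2c(C)nn(C)c2Oc2ccccc2OC)c1Cl`, differs from compound 3 by methoxy in place of methyl on an aromatic carbon. Among the measured compounds shown here, no measured step bears on this change with a readable size. For the measured compounds named here, the only guidance is that every compound shown sits at the limit, so compound 4 is expected to sit there too. The expected step that the limit leaves unreadable from compound 3 to compound 4 is estimated to be nothing beyond the scatter. Compound 4 is accordingly expected to give 35% in this assay, with a range from 5% to 75%, and most likely the assay will again report only a limit.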

Compound 4, a percentage reported as inhibition, at one concentration (the size of the read-out at that concentration, not a potency): < 80%
Compound 4 ended at the assay's limit; the forecaster's own chance of this, stated with the estimate: 85%; the middle value is on the limit's open side.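

No step to compound 4 from compound 1, compound 2 or compound 3 can be read in this assay, since all of them end at a limit of the assay: the limit of < 80% in this assay, at which 4 of the 4 values shown sit.

The compounds shown leave open whether methoxy in place of methyl on the aromatic carbon changes inhibition at all.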